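The compounds below may be only part of what the source reports. "The series", "measured", "known", "first", "only" and "open" are said of these compounds alone.

Measured so far in a functional assay on ASK cells (Rattus norvegicus) for cytotoxicity, read by sulforhodamine B assay; on this read-out lower numbers stand for an effect already at smaller amounts and higher numbers for an effect only at larger amounts of compound:
- compound 1 `C=C1CC[C@@H]2[C@](C)(CO)[C@H](OC(C)=O)CC[C@@]2(C)[C@@H]1C/C=C1/C(=O)OC[C@H]1O` gives 58.1 uM
- compound 2 `C=C1CC[C@@H]2[C@](C)(CO[Si](C)(C)C(C)(C)C)[C@H](OC(C)=O)CC[C@@]2(C)[C@@H]1C/C=C1/C(=O)OC[C@H]1OC(C)=O` gives 1.22 uM
- compound 3 `C=C1CC[C@@H]2[C@](C)(CO[Si](C)(C)C(C)(C)C)[C@H](O)CC[C@@]2(C)[C@@H]1C/C=C1/C(=O)OC[C@H]1O` gives 15.5 uM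

Compound 3 holds the middle place of the three numbers, with compound 1 higher and compound 2 lower, both gaps beyond the scatter. Compound 4 `C=C1CC[C@@H]2[C@](C)(CO[Si](C)(C)C(C)(C)C)[C@H](OC(C)=O)CC[C@@]2(C)[C@@H]1C/C=C1/C(=O)OC[C@H]1O` follows from compound 3 by one change: acetyl in place of hydrogen on an oxygen on a saturated carbon, or hydroxy to acetoxy.

Among the measured compounds shown here, no single-change step has been measured, so the expectation rests on indirect evidence. Compound 2 at 1.22 uM carries this acetoxy along with a second acetyl group, which suggests that compound 4 covers only part of the gap. Compound 1 at 58.1 uM also carries this acetoxy and goes against any simple rule that acetoxy alone gives a low number. A moderate move to a lower number is expected, an estimated 2.2-fold lower number from compound 3 to compound 4 (0.35 log units; beyond the scatter) in this assay overall. The estimate for compound 4 is 7 uM with an expected range of 2.5 uM to 20 uM in this read-out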

Compound 4, concentration for half-maximal effect: 8.17 uM
Compound 4: the middle estimate sits 1.2-fold (0.07 log units) below what was measured; the range from low to high includes it.
By their numbers in this assay, from the lowest: compound 2; then compounds 4 and 3 (each within the scatter of the next); then compound 1.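

In this assay acetyl in place of hydrogen on this oxygen on a saturated carbon gives a 1.9-fold lower number from compound 3 to compound 4 (0.28 log units; within the scatter) and so, taken alone, hydroxy to acetoxy at this position does not separate the two compounds. Steps beyond the scatter appear at the other two places: hydrogen in place of acetyl on a second oxygen gives a 6.7-fold higher number from compound 2 to compound 4 (0.83 log units; beyond the scatter) and the silicon-bearing group in place of hydrogen on a third oxygen gives a 7.1-fold lower number from compound 1 to compound 4 (0.85 log units; beyond the scatter) in the same series. No measured property bears on these steps, and the data offer no explanation for them.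

On these data alone, whether the acetyl on the second oxygen gives a step of similar size when this position carries a free hydroxy stays open. Also open, as far as these compounds go, is how a longer ester such as butanoyl, or an amine in place of the oxygen, would read at this position.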